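The source may hold more compounds than are shown below. What is called first, only, known or untested is meant among the compounds shown, and "the series" means these compounds.

Compound 1 `O=c1[nH]cc(S(=O)(=O)Nc2ccccc2-c2cn(-c3ccccc3F)nn2)c(=O)[nH]1` gives 12500 nM in a functional assay on HepG2 cells (Homo sapiens) for antiproliferative activity, read by MTT assay, with a stated time of 24 h; a higher number here means a weaker inhibitor, a lower number a stronger inhibitor.
Compound 2 `O=c1[nH]cc(S(=O)(=O)Nc2ccccc2-c2cn(-c3cccc(F)c3)nn2)c(=O)[nH]1` reaches only the limit > 20000 nM in this assay.
Compound 3 `O=c1[nH]cc(S(=O)(=O)Nc2ccc(-c3cn(-c4ccccc4F)nn3)cc2)c(=O)[nH]1` likewise reaches only the limit > 20000 nM in this assay.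

Compound 2 differs from compound 1 by 3-fluorophenyl in place of 2-fluorophenyl on an aromatic nitrogen. That change produced an at least 1.6-fold higher number from compound 1 to compound 2 (0.20 log units; that floor lies within the scatter); the floor of that step comes from the limit of > 20000 nM in this assay, at which 2 of the 3 values shown sit. The difference between the core of compound 1 and the core of compound 3 is not broken down here. Compound 4 `O=c1[nH]cc(S(=O)(=O)Nc2ccc(-c3cn(-c4cccc(F)c4)nn3)cc2)c(=O)[nH]1` has not yet been measured; it differs from compound 3 by 3-fluorophenyl in place of 2-fluorophenyl on an aromatic nitrogen, the same change made at the same kind of place. Since compound 3 already sits at the limit, compound 4 is expected to show a step that the limit leaves unreadable from compound 3 to compound 4 in this assay, an expectation that rests on an at least 1.6-fold higher number from compound 1 to compound 2 (0.20 log units; that floor lies within the scatter). Compound 4 is therefore estimated at 32000 nM in this assay, with a range from 15000 nM to 80000 nM, and will most likely be reported again only as a limit.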

Compound 4, half-maximal inhibitory concentration: > 20000 nM
Compound 4: a limit, no number; the forecaster's own chance of this, stated with the estimate: 85%; the middle value lies beyond the limit too.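

In this assay no step can be read between compound 3 and compound 4, as each gives only a limit, not a number: the limit of > 20000 nM in this assay, at which 3 of the 4 values shown sit.

On these data alone, whether 3-fluorophenyl in place of 2-fluorophenyl changes activity on the core of compound 3 stays open.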